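The compounds below may be only part of what the source reports. "The series", "measured", "known", "first", "only" and "open" are said of these compounds alone.

Measured in an assay for binding affinity to Alpha-1B adrenergic receptor (Homo sapiens); on this read-out lower numbers stand for stronger inhibition and higher numbers for weaker inhibition:
Compound 1 `CN1CCC[C@@H]1Cn1nc(Cc2cccc(Cl)c2)c2ccccc2c1=O` gives 631 nM.
Compound 2 `CN(C)CCn1nc(Cc2ccc(Cl)cc2)c2ccccc2c1=O` gives 200 nM.
Compound 3 `CN1CCC[C@@H]1Cn1nc(Cc2ccc(C(C)(C)C)cc2)c2ccccc2c1=O` gives > 1990 nM, which is a limit of the assay rather than a number.

Of the two numbers shown, compound 1 holds the higher one, and compound 2 sits lower by a gap beyond the usual scatter. Compound 3 sits at the limit of > 1990 nM in this assay, at which 1 of the 3 values shown sits.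

Compound 4 `CCCCCc1nn(C[C@H]2CCCN2C)c(=O)c2ccccc12` has not yet been measured. Compared with compound 1, the change is butyl in place of 3-chlorophenyl on a saturated chain carbon bound to an aromatic carbon; cut one bond further out, the same difference reads 3-chlorobenzyl to pentyl. Going by the values given here, none of the measured pairs differ in just one place, so no measured step shows what swapping an aromatic ring for a plain chain does here. The expectation is that the step from compound 1 to compound 4 moves toward a weaker number, beyond the scatter, as a 2.5-fold higher number from compound 1 to compound 4 (0.40 log units; beyond the scatter). For compound 4 the estimated value is 1600 nM, expected to fall between 400 nM and 6000 nM, with a real chance that only a limit is reported.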

Compound 4, inhibition constant: 1000 nM
Compound 4: middle estimate off by 1.6-fold (0.20 log units), on the high side; measured number inside the range.
By their numbers in this assay, from the lowest: compound 2; then compounds 1 and 4 (each within the scatter of the next). At a limit, above all of these: compound 3.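

The first single-place change seen in this assay puts butyl in place of 3-chlorophenyl on a saturated chain carbon bound to an aromatic carbon, and it gives a 1.6-fold higher number from compound 1 to compound 4 (0.20 log units; within the scatter) and so no real change in the read-out. For this one pair, then, the chlorinated aromatic ring is not needed to keep the number where compound 1 has it, and a plain chain with no ring reads the same. Nothing shown here explains why these two groups read alike.

One pair cannot say how far this holds at this place: a shorter chain such as ethyl, or a chain ending in an amine, could read quite differently. Also open, from the compounds shown here alone, is whether butyl would read the same on compound 2 in place of its chlorinated ring.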